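Swapping the Amine Substituent on the Pyridine Core

A few compounds are considered here, and "the series" means these few. Any claim that something is new, unique, unknown or untested is made for them only; others in the source may bear on it.

Measured compounds:
compound 1 `CC(C(=O)NCc1ccc(C(F)(F)F)nc1NC1CCCCC1)c1ccc(NS(C)(=O)=O)c(F)c1` — 260 nM
compound 2 `CCCN(CCC)c1nc(C(F)(F)F)ccc1CNC(=O)C(C)c1ccc(NS(C)(=O)=O)c(F)c1` — 14.7 nM
compound 3 `C[C@H](C(=O)NCc1ccc(C(F)(F)F)nc1N1CCC[C@H]1CO)c1ccc(NS(C)(=O)=O)c(F)c1` — "not active" (no number reported) (no number reported)

These three share one core and differ only in the group carried on the aromatic carbon next to the ring nitrogen. In a functional assay on CHO-K1 cells for antagonist activity at transient receptor potential cation channel subfamily V member 1 (Homo sapiens), read by FLIPR (on this read-out higher numbers stand for weaker inhibition and lower numbers for stronger inhibition), compound 2 gives the lowest number of the two that were reported; its nearest neighbour is compound 1, and the step of an 18-fold lower number from compound 1 to compound 2 (1.25 log units; beyond the scatter) is large, beyond the scatter. Compound 3, which carries a ring on that carbon, gave "not active" (no number reported) and no number at all.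

Compound 4 `CC(=O)OC1CCN(c2nc(C(F)(F)F)ccc2CNC(=O)C(C)c2ccc(NS(C)(=O)=O)c(F)c2)CC1` has not yet been measured. Its change from compound 2 is 4-acetoxypiperidin-1-yl in place of dipropylamino on an aromatic carbon. Among the compounds with values here, the one measured step that bears on this position, an 18-fold lower number from compound 1 to compound 2 (1.25 log units; beyond the scatter), shows that leaving dipropylamino cost a great deal of inhibition; compound 3 points the same way. A ring group is therefore expected to raise the number, and the estimated step is a 10-fold higher number from compound 2 to compound 4 (1.01 log units; beyond the scatter). For compound 4 the estimate is 150 nM, within 25 nM to 1500 nM.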

Compound 4, half-maximal inhibitory concentration: 139 nM
Estimate against measurement, compound 4: 1.1-fold (0.03 log units) above, and the stated range covers the measured number.
By their numbers in this assay, from the lowest: compound 2; then compounds 4 and 1 (each within the scatter of the next).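

In this assay, compound 4 shows that a ring group on this carbon can still give a measured number, which compound 3 did not show, but a 9.5-fold higher number from compound 2 to compound 4 (0.98 log units; beyond the scatter) is a step beyond the scatter, and dipropylamino keeps the lowest number. The other comparison, a 1.9-fold lower number from compound 1 to compound 4 (0.27 log units; within the scatter), lies within the scatter, so 4-acetoxypiperidin-1-yl and cyclohexylamino cannot be told apart here, although they differ in size and in their atoms. Nothing measured here explains either step.

As far as these compounds go, compound 4 brings in the ring and the acetoxy group together, so their separate shares in the step from dipropylamino remain open; a plain piperidin-1-yl group or a piperidine carrying a hydroxyl group would separate them. From the compounds shown here alone, whether a longer chain on the amine, such as dibutylamino, lowers the number further also remains open.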